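Nitro for dimethoxy on the ring carbon: an untested step

The compounds below may be only part of what the source reports. "The series", "measured", "known", "first", "only" and "open" are said of these compounds alone.

Measured so far:
compound 1 `COc1ccc(C2N=C(SCc3ccccc3)NC(C)=C2C(=O)Nc2ccc(F)cc2)cc1OC` — 1.5%
compound 2 `COc1ccc(C2N=C(SCc3cccc(Cl)c3)NC(C)=C2C(=O)Nc2ccc(F)cc2)cc1OC` — 2.1%
compound 3 `COc1ccc(C2N=C(SCc3ccc(Cl)cc3)NC(C)=C2C(=O)Nc2ccc(F)cc2)cc1OC` — 3.1%

In a functional assay on the whole organism (artery, strain albino) with Rattus norvegicus as the target, with a stated time of 15 min, at a dose of 10 mg/kg by the oral route (a lower number here means less inhibition, a higher number more inhibition at the dose given (going by the name of the read-out)), compound 1 gives 1.5%, the lowest of the three numbers, though neither neighbour is separated from it beyond the scatter: a number 0.6 percentage points higher from compound 1 to compound 2 (within the scatter) and a number 1.6 percentage points higher from compound 1 to compound 3 (within the scatter), while a number 1 percentage points higher from compound 2 to compound 3 (within the scatter). All three measured steps alter only the benzylsulfanyl group.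

Compound 4 `CC1=C(C(=O)Nc2ccc(F)cc2)C(c2ccc([N+](=O)[O-])cc2)N=C(SCc2ccccc2)N1` differs from compound 1 elsewhere: 4-nitrophenyl in place of 3,4-dimethoxyphenyl on a saturated ring carbon. Within the data shown here, no measured step touches this saturated ring carbon, so none bears directly on it; the three measured steps are all small and within the scatter, and every number is low. Compound 4 is therefore expected to stay near compound 1, with a number 1.5 percentage points higher from compound 1 to compound 4 (within the scatter). The estimate for compound 4 is 3%, ranging from 0% to 15%.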

Compound 4, a percentage reported as inhibition, in the whole organism at one dose (the size of the read-out at that dose, not a potency): 3.1%
Compound 4: middle estimate off by 0.1 percentage points, on the low side, and the stated range covers the measured number.
By their numbers in this assay, from the lowest: compounds 1, 2, 3 and 4 (each within the scatter of the next).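

Unlike the three steps on the benzylsulfanyl group, this one changes the saturated ring carbon, and in this assay 4-nitrophenyl in place of 3,4-dimethoxyphenyl gives a number 1.6 percentage points higher from compound 1 to compound 4 (within the scatter) at this dose. Replacing this aryl group therefore stays within the scatter, as the benzylsulfanyl changes did. No measurement here accounts for the result. Still open, from the compounds shown here alone, is whether any group on this carbon moves the number beyond the scatter, such as a 4-aminophenyl or 4-carboxyphenyl group, or a saturated ring or alkyl chain instead of an aromatic ring.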